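An Aminopyrimidine Ketone in Place of the Methoxyphenyl Ketone

This account rests on a few compounds, and the source may have more. Where it says the series, first, only, none or still open, it means among the compounds named here.

Compound 2 `COc1ccc(C(=O)/C=C/c2nc3ccccc3cc2-c2ccc(OC)cc2)cc1` carries a 4-methoxyphenyl on the carbonyl carbon; in a functional assay on MCF7 cells (Homo sapiens) for antiproliferative activity, read by XTT assay, with a stated time of 72 h (on this read-out lower numbers stand for stronger inhibition and higher numbers for weaker inhibition), compound 2 gives 7380 nM. Compound 1 `COc1ccc(-c2cc3ccccc3nc2/C=C/C(=O)c2ccccc2)cc1` has hydrogen where compound 2 has methoxy on an aromatic carbon, and in this assay compound 1 gives 4040 nM; the step is a 1.8-fold higher number from compound 1 to compound 2 (0.26 log units; within the scatter). Of the two numbers, compound 2 is the higher, with compound 1 nearest. Compound 3 `COc1ccc(-c2cc3ccccc3nc2/C=C/C(=O)c2ccc[nH]2)cc1`, with 1H-pyrrol-2-yl on the carbonyl carbon, reaches only the limit > 10000 nM in this assay (the limit of > 10000 nM in this assay, at which 1 of the 3 values shown sits). The relevant steps are an at least 1.3-fold higher number from compound 2 to compound 3 (0.13 log units; that floor lies within the scatter) and an at least 2.4-fold higher number from compound 1 to compound 3 (0.39 log units; beyond the scatter). Compound 4 `COc1ccc(-c2cc3ccccc3nc2/C=C/C(=O)c2cnc(N)nc2C)cc1` is unmeasured; the change is 2-amino-4-methylpyrimidin-5-yl in place of 4-methoxyphenyl on a carbonyl carbon. Because the only other ring tried on that carbonyl carbon gave an at least 1.3-fold higher number from compound 2 to compound 3 (0.13 log units; that floor lies within the scatter), compound 4 is expected to shift a 1.6-fold higher number from compound 2 to compound 4 (0.21 log units; within the scatter). Compound 4 is estimated at 12000 nM, ranging from 4500 nM to 30000 nM.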

Compound 4, half-maximal inhibitory concentration: > 10000 nM
Compound 4: no number, only a limit (the forecaster's own chance of this, stated with the estimate: 55%); the middle value lies beyond the limit too.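

In this assay, 2-amino-4-methylpyrimidin-5-yl joins 1H-pyrrol-2-yl as a second ring on the carbonyl carbon that yields only a limit: the limit of > 10000 nM in this assay, at which 2 of the 4 values shown sit. The change gives an at least 2.4-fold higher number from compound 1 to compound 4 (0.39 log units; beyond the scatter), and it gives an at least 1.3-fold higher number from compound 2 to compound 4 (0.13 log units; that floor lies within the scatter). The step between compound 3 and compound 4 cannot be read, as both values are limits.

On these data alone, how far compound 3 and compound 4 lie beyond that limit stays open. Also open, as far as these compounds go, is whether a pyridine ring or a plain methyl on the carbonyl carbon would give a measurable number.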